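Flipping one ring stereocentre in a cyclic peptide

The source may hold more compounds than are shown below. What is called first, only, known or untested is meant among the compounds shown, and "the series" means these compounds.

Two cyclic peptides have been measured. In an assay on a protein complex for binding affinity to integrin alpha-5/beta-1 (Homo sapiens), read by ELISA (on this read-out lower numbers stand for stronger inhibition and higher numbers for weaker inhibition), compound 1 `CC(C)[C@H]1NC(=O)[C@H](CCCNC(=N)N)NC(=O)CNC(=O)C[C@@H](C(=O)O)NC(=O)[C@@H](c2ccccc2)NC1=O` gives 7.3 nM, while compound 2 `N=C(N)NCCC[C@@H]1NC(=O)CNC(=O)C[C@@H](C(=O)O)NC(=O)[C@@H](c2ccccc2)NC(=O)[C@@H]2CCCN2C1=O` gives 111 nM, the higher of the two numbers and a gap beyond the scatter. Compound 3 `N=C(N)NCCC[C@@H]1NC(=O)CNC(=O)C[C@@H](C(=O)O)NC(=O)[C@@H](c2ccccc2)NC(=O)[C@H]2CCCN2C1=O` keeps every atom and bond of compound 2; the only difference is the two compounds have the same atoms and bonds; at least one stereo element is drawn with a configuration in one of them and without one in the other: 1 of 5 stereo elements differ; a stereocentre at a saturated ring carbon is drawn S in compound 2 and R in compound 3. Among the compounds with values here, no pair of measured compounds shows what such an inversion does here, so the direction is uncertain, but a step beyond the scatter seems likely. The step from a 1.9-fold lower number from compound 2 to compound 3 (0.27 log units; within the scatter) is an estimate only. For compound 3 the expected value is 60 nM, in a range from 6 nM to 700 nM.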

Compound 3, half-maximal inhibitory concentration: 7 nM
Compound 3: middle estimate off by 8.6-fold (0.93 log units), on the high side; low and high end bracket the measured number.
By their numbers in this assay, from the lowest: compounds 3 and 1 (each within the scatter of the next); then compound 2.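

In this assay inverting a stereocentre at a saturated ring carbon from S to R gives a 16-fold lower number from compound 2 to compound 3 (1.20 log units; beyond the scatter) while every atom and bond stays the same. The three-dimensional arrangement at this single carbon therefore matters greatly, and here the R form gives the lower number. The only structural basis for this step is: the fact that one of compounds 2 and 3 is drawn with a defined configuration and the other without, at the place where they differ.

Going by these compounds, whether inverting any of the other stereocentres has a similar effect remains open. So does whether the R form keeps its advantage with a hydroxyl group on that same ring.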